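Fluoro scan on the fused-ring amine of the quinoline series

This account rests on a few compounds, and the source may have more. Where it says the series, first, only, none or still open, it means among the compounds named here.

Measured compounds and their values in an ADME assay on HEp-2 cells (Homo sapiens) for cytotoxicity, read by CCK-8 assay, with a stated time of 5 days; a higher number here means that more compound is tolerated, a lower number that less compound is tolerated:
- Compound 1 `Cc1ccc2nc(N3CCCc4ccc(F)cc4C3)cc(NCC3(N)COC3)c2c1` gives > 100000 nM, which is a limit of the assay, not a number.
- Compound 2 `Cc1ccc2nc(N3CCCc4ccccc4C3)cc(NCCN)c2c1` gives 9400 nM.
- Compound 3 `Cc1ccc2nc(N3CCCc4cc(F)ccc4C3)cc(NCCN)c2c1` gives > 3200 nM, which is a limit of the assay, not a number.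

Among the measured compounds shown here, compound 2 is the only compound with a number in this assay; the other two values are limits. The step that the limit leaves unreadable from compound 2 to compound 3 cannot be sized, because compound 3 sits at the limit of > 3200 nM in this assay, at which 1 of the 3 values shown sits.

Compound 4 `Cc1ccc2nc(N3CCCc4ccc(F)cc4C3)cc(NCCN)c2c1` differs from compound 2 by fluoro in place of hydrogen on an aromatic carbon. Compound 1 carries the same fluoro at the same place on a different side chain and sits at the limit of > 100000 nM in this assay, at which 1 of the 3 values shown sits, which gives no readable size either. For the measured compounds named here, no measured step bears on the change from compound 2 to compound 4 with a readable size, so no shift beyond the usual scatter is expected for compound 4 in this assay; the estimated step is a 1.3-fold higher number from compound 2 to compound 4 (0.11 log units; within the scatter).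

Compound 4 is expected to give about 12000 nM, with a range from 4000 nM to 40000 nM.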

Compound 4, half-maximal cytotoxic concentration: > 3200 nM
Compound 4 ended at the assay's limit; the forecaster's own chance of this, stated with the estimate: 30%; the middle value lies beyond the limit too.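

In this assay compound 4 gives > 3200 nM, a limit and not a number; the steps to it from compound 2 and from compound 1 cannot be read. From the compounds shown here alone, whether fluoro in place of hydrogen on an aromatic carbon shifts the value of compound 2 at all, in compound 3 or compound 4, stays open.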